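The compounds below may be only part of what the source reports. "The series", "measured", "known", "first", "only" and "open" are said of these compounds alone.

Compound 3 `C=CCn1c(=O)/c(=C\c2ccc(C)cc2)[nH]c(=O)/c1=C\c1ccccc1OC` is the reference point here. In a functional assay on HL-60 cells (Homo sapiens) for cytotoxicity, read by CCK-8 assay, with a stated time of 72 h (a higher number here means a weaker inhibitor, a lower number a stronger inhibitor), compound 3 is recorded as "not active" (no number reported), so it stands without a single number, only the report that it did not show measurable cytotoxicity. For comparison, compound 1 `C=CCn1c(=O)/c(=C\c2cccc(C)c2)[nH]c(=O)/c1=C\c1ccccc1OC` gives 16700 nM in this assay, and compound 2 `C=CCn1c(=O)/c(=C\c2cccc(Cl)c2)[nH]c(=O)/c1=C\c1ccccc1OC` gives 4500 nM.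

Compound 4 `C=CCn1c(=O)/c(=C\c2ccccc2Cl)[nH]c(=O)/c1=C\c1ccccc1OC` differs from compound 3 by the change (2-chlorophenyl in place of 4-methylphenyl on a double-bonded chain carbon bound to an aromatic carbon). For the measured compounds named here, only one measured step speaks to this: a 3.7-fold lower number from compound 1 to compound 2 (0.57 log units; beyond the scatter). That step exchanges the same two groups, chloro for methyl, though at a different place on the ring, and it points toward a stronger inhibitor. Going by the values given here, no measured pair tells how moving the substituent around the ring affects this assay, so the ring-position part of the change is uncharted, and compound 3 itself offers no number to anchor a step.

On the strength of compound 2 and its value 4500 nM, compound 4 is expected to be measurable and weaker, around 8000 nM, somewhere between 2500 nM and 30000 nM.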

Compound 4, half-maximal inhibitory concentration: 4200 nM
The estimate for compound 4 lay 1.9-fold (0.28 log units) above the measured number; the range from low to high includes it.
By their numbers in this assay, from the lowest: compounds 4 and 2 (each within the scatter of the next); then compound 1.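

In this assay, the position of the chlorine on the ring makes no visible difference between these two compounds: 2-chlorophenyl in place of 3-chlorophenyl gives a 1.1-fold lower number from compound 2 to compound 4 (0.03 log units; within the scatter). The same group in place of 3-methylphenyl gives a 4.0-fold lower number from compound 1 to compound 4 (0.60 log units; beyond the scatter), so both chlorophenyl compounds stand apart from compound 1, while compound 3, with 4-methylphenyl, has no number and any step from it cannot be read. No measurement shown here accounts for these differences.

The compounds shown leave open whether 4-chlorophenyl or 2-methylphenyl on this carbon would give a measurable number, which would separate the effect of the group from that of its ring position. They also leave open how a phenyl ring carrying an amine or a carboxylic acid would fare in this assay.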